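A few compounds are considered here, and "the series" means these few. Any claim that something is new, unique, unknown or untested is made for them only; others in the source may bear on it.

Measured in a functional assay on HEK293 cells (Homo sapiens) for cytotoxicity; on this read-out higher numbers stand for lower toxicity in this test and lower numbers for higher toxicity in this test:
Compound 1 `COc1ccc([C@H]2CC(=O)N(c3cccc(C)c3)C2)cc1OC1CCCC1` gives > 10000 nM as a limit
Compound 2 `COc1ccc([C@H]2CC(=O)N(c3cccc(NS(=O)(=O)c4cccc(Cl)c4C)c3)C2)cc1OC1CCCC1` gives > 10000 nM as a limit
Compound 3 `COc1ccc([C@H]2CC(=O)N(c3cccc(NS(=O)(=O)c4ccccc4Cl)c3)C2)cc1OC1CCCC1` gives > 10000 nM as a limit

Compound 3 has no number of its own and stands with the rest of the series at the limit: the limit of > 10000 nM in this assay, at which 3 of the 3 values shown sit, applies to it.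

Compound 4 `COc1ccc([C@H]2CC(=O)N(c3cccc(NS(=O)(=O)c4cccc(Cl)c4)c3)C2)cc1OC1CCCC1` has 3-chlorophenyl in place of 2-chlorophenyl on a sulfonyl sulfur, and the counted difference is 3-chlorophenyl in place of 2-chlorophenyl on a sulfonyl sulfur with the rest of compound 3 unchanged.

The nearest measured change is a step that the two limits leave unreadable from compound 2 to compound 3 at the same sulfonyl sulfur. The two changes that bring in the sulfonamide, a step that the two limits leave unreadable from compound 1 to compound 2 and a step that the two limits leave unreadable from compound 1 to compound 3 give no size either. No size can be carried over, so no step beyond the scatter is expected in this assay in either direction.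

The expected change is a step that the limit leaves unreadable from compound 3 to compound 4 and a further limit is the likely report. Compound 4 is expected at 15000 nM (7000 nM to 40000 nM).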

Compound 4, half-maximal cytotoxic concentration: > 10000 nM
Compound 4: a limit, no number (the forecaster's own chance of this, stated with the estimate: 90%); the middle value is on the limit's open side.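

In this assay compound 4 is again reported only as a limit, so no step from compound 1, compound 2 or compound 3 to compound 4 can be read: the limit of > 10000 nM in this assay, at which 4 of the 4 values shown sit.

The compounds shown leave open whether 3-chlorophenyl and 2-chlorophenyl on the sulfonyl sulfur differ at all, and whether any member of the series gives a readable number.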